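Swapping one group on compound 3

The compounds below may be only part of what the source reports. "The series", "measured", "known", "first", "only" and "open" are said of these compounds alone.

Values from a functional assay on OVCAR-3 cells (Homo sapiens) for antiproliferative activity, read by MTT assay, with a stated time of 24 h (on this read-out lower numbers stand for stronger inhibition and higher numbers for weaker inhibition), follow
- Compound 1 `O=C(NNc1cccc(Cl)c1)c1ccc(NS(=O)(=O)c2cnc(O)nc2O)cc1` gives 8410 nM
- Compound 2 `Cc1cccc(NNC(=O)c2cccc(NS(=O)(=O)c3cnc(O)nc3O)c2)c1` gives > 20000 nM as a limit, not a number
- Compound 3 `O=C(NNc1ccccc1F)c1ccccc1NS(=O)(=O)c1cnc(O)nc1O` gives 9570 nM

Among the compounds with values here, compound 3 (9570 nM) lies within the scatter of compound 1 (8410 nM), and these two hold the only actual numbers in the set. Compound 4 `O=C(NNC(=O)c1ccccc1NS(=O)(=O)c1cnc(O)nc1O)c1ccccc1Cl` carries (2-chlorophenyl)carbonyl in place of 2-fluorophenyl on an amine nitrogen. Within the data shown here, no measured pair shows what a single change does here, so the expectation starts from compound 3 (9570 nM) and stays cautious. The estimated step of a 1.1-fold higher number from compound 3 to compound 4 (0.06 log units; within the scatter) is expected to remain inside the usual scatter. For compound 4 the expected value is 11000 nM with an estimated range from 4500 nM to 20000 nM in this measurement.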

Compound 4, half-maximal inhibitory concentration: 18200 nM
Compound 4: the middle estimate sits 1.7-fold (0.22 log units) below what was measured, and the stated range covers the measured number.
By their numbers in this assay, from the lowest: compounds 1, 3 and 4 (each within the scatter of the next, the first and the last beyond it). At a limit, above all of these: compound 2.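

Within the data shown here, this is the first step in the set that differs in one place: (2-chlorophenyl)carbonyl in place of 2-fluorophenyl on an amine nitrogen gives a 1.9-fold higher number from compound 3 to compound 4 (0.28 log units; within the scatter) in this assay. A carbonyl and a chlorine thus enter together here and an actual number remains, though a single step cannot separate the two. Compound 2 stands at a limit, not a number: the limit of > 20000 nM in this assay, at which 1 of the 4 values shown sits.

Still open, going by these compounds, is what a (2-fluorophenyl)carbonyl would give on this nitrogen, which would set the carbonyl apart from the chlorine. Also open, on these data alone, is how a longer alkyl chain or a carboxylic acid would read in this place.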